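Thienopyrimidinyl ether pyridazinone amides: HepG2 cytotoxicity notes

The source may report more compounds than this note shows. Statements on the series, on what has been measured and on what is new or still open speak of the compounds shown alone.

Measured so far in a functional assay on HepG2 cells (Homo sapiens) for cytotoxicity, read by MTT assay, with a stated time of 72 h; a higher number here means a weaker inhibitor, a lower number a stronger inhibitor:
- compound 1 `Cc1cc(=O)n(-c2ccc(Br)cc2F)nc1C(=O)Nc1ccc(Oc2ncnc3ccsc23)cc1` gives 10600 nM
- compound 2 `Cc1cc(=O)n(-c2ccccc2OC(F)(F)F)nc1C(=O)Nc1ccc(Oc2ncnc3ccsc23)c(F)c1` gives 15700 nM
- compound 3 `Cc1cc(=O)n(-c2ccc(Br)cc2F)nc1C(=O)Nc1ccc(Oc2ncnc3sccc23)cc1` gives 6300 nM

Compound 3 stands at the lowest number of the three in this assay. Its gap to compound 1 is small: a 1.7-fold lower number from compound 1 to compound 3 (0.23 log units; within the scatter), a swap of one bicyclic ether group for another on the ring oxygen. For the measured compounds named here, compound 2 sits furthest from compound 3, but compound 2 differs from compound 3 in more than one place, so the two values show only that compound 2 gives a higher number.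

The next compound, compound 4 `Cc1cc(=O)n(-c2ccc(F)cc2)nc1C(=O)Nc1ccc(Oc2ncnc3sccc23)cc1`, differs from compound 3 only on the aromatic nitrogen of the pyridazinone: 4-fluorophenyl in place of 4-bromo-2-fluorophenyl on an aromatic nitrogen. Going by the values given here, none of the measured steps changes this group alone, so there is no direct precedent for its effect in this assay. Among the compounds with values here, the one single-site step available, from compound 1 to compound 3, lies within the scatter and concerns a different part of the molecule.

Without a bearing step, compound 4 is expected to stay close to compound 3, with the step of a 1.3-fold higher number from compound 3 to compound 4 (0.10 log units; within the scatter) not reaching beyond the scatter. Compound 4 is therefore estimated at 8000 nM, within a range of 3500 nM to 20000 nM in this assay.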

Compound 4, half-maximal inhibitory concentration: 6460 nM
Beside the measured number, compound 4's estimate is 1.2-fold (0.09 log units) above it, within the range that was stated.
By their numbers in this assay, from the lowest: compounds 3, 4, 1 and 2 (each within the scatter of the next, the first and the last beyond it).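

In this assay, for the compounds shown here, the step of a 1.0-fold higher number from compound 3 to compound 4 (0.01 log units; within the scatter) gives the first single-site reading of the group on the aromatic nitrogen, as the only earlier single-site step concerned the group on the oxygen. With the ether group of compound 3 held constant, 4-fluorophenyl in place of 4-bromo-2-fluorophenyl gives no difference that this assay can resolve, a finding limited to this one pair. Nothing measured alongside these numbers bears on this result, so it can be given no explanation.

Going by these compounds, it remains open whether the position stays equally unresponsive when the phenyl ring carries something other than halogen, such as an amine or a carboxylic acid, or when a saturated ring such as cyclohexyl replaces the phenyl ring altogether. On these data alone, it is also open whether the same swap reads the same way with the ether group of compound 1, since the single-site reading at this position rests only on the ether group shared by compound 3 and compound 4.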